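Shortening the Alkyl Chain of Compound 3

The source may hold more compounds than are shown below. What is called first, only, known or untested is meant among the compounds shown, and "the series" means these compounds.

Compound 3 `CCCCCCCCCCCCCCCCCC/N=c1\nc(N)c2ncn(Cc3ccccc3)c2c(N)n1` gives 8300 nM in a functional assay on MCF7 cells (Homo sapiens) for antiproliferative activity, read by WST assay, with a stated time of 72 h (a higher number here means a weaker inhibitor, a lower number a stronger inhibitor), the second highest of the three numbers: compound 2 `Nc1n/c(=N\CCCCc2ccccc2)nc(N)c2c1ncn2Cc1ccccc1` gives 8800 nM, within the scatter of it, while compound 1 `CCCCCCCCCCCCCCCCCC/N=c1\nc(N)c2nc[nH]c2c(N)n1` gives 3530 nM, and a 2.4-fold higher number from compound 1 to compound 3 (0.37 log units; beyond the scatter). Compound 4 `CCCCCCCCCCCCCC/N=c1\nc(N)c2ncn(Cc3ccccc3)c2c(N)n1` differs from compound 3 by hydrogen in place of butyl on a saturated chain carbon, ten or more bonds along the chain from a double-bonded nitrogen. For the measured compounds named here, no measured step alters this chain; the one measured step concerns the benzyl on the aromatic nitrogen and does not bear on it, and compound 2 carries an altogether different group on the double-bonded nitrogen. With nothing pointing either way, no step beyond the scatter is expected, and compound 4 is estimated at 8000 nM, between 3000 nM and 20000 nM, which means a 1.0-fold lower number from compound 3 to compound 4 (0.02 log units; within the scatter).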

Compound 4, half-maximal inhibitory concentration: 4100 nM
The estimate for compound 4 lay 2.0-fold (0.29 log units) above the measured number, and the stated range covers the measured number.
By their numbers in this assay, from the lowest: compounds 1 and 4 (each within the scatter of the next); then compounds 3 and 2 (each within the scatter of the next).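

In this assay, for the compounds shown here, the alkyl chain on the double-bonded nitrogen proves responsive to length: hydrogen in place of butyl on a saturated chain carbon gives a 2.0-fold lower number from compound 3 to compound 4 (0.31 log units; beyond the scatter) and is the first measured step at this place. Decyl in place of phenyl, four bonds along the chain, gives a 2.1-fold lower number from compound 2 to compound 4 (0.33 log units; beyond the scatter) and so sets a chain ending in alkyl apart from one ending in phenyl. As far as these compounds go, whether a still shorter chain such as octyl would continue this step remains open, as does the effect of an amine or a carboxylic acid at the chain end. No evidence at hand accounts for either step.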